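Series notes: acrylamide tail variations on a shared core

The source may hold more compounds than are shown below. What is called first, only, known or untested is meant among the compounds shown, and "the series" means these compounds.

Measured so far:
- compound 1, `C/C=C/C(=O)Nc1cccc(-c2nc3ccccc3s2)c1`, > 25000 nM
- compound 2, `C=C(C)C(=O)Nc1cccc(-c2nc3ccccc3s2)c1`, > 25000 nM

Both values are limits of the assay rather than numbers. In an ADME assay on Raji cells (Homo sapiens) for inhibition, with a stated time of 72 h (a higher number here means that more compound is needed for the effect, a lower number that less compound is needed), compound 1 reaches only the limit > 25000 nM. In this assay compound 2 likewise reaches only the limit > 25000 nM. Within the data shown here, the single measured step, a step that the two limits leave unreadable from compound 1 to compound 2, cannot be read because both ends sit at the limit (the limit of > 25000 nM in this assay, at which 2 of the 2 values shown sit), so compound 2 stands where compound 1 stands: at the edge of what this assay can report.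

The next compound, compound 3, `O=C(O)/C=C/C(=O)Nc1cccc(-c2nc3ccccc3s2)c1`, differs from compound 2 by the change (2-carboxyethenyl in place of 1-methylethenyl on a carbonyl carbon). Among the measured compounds shown here, no measured step bears on this change, and the one step that is recorded is unreadable. There is therefore no basis for expecting a readable step beyond the scatter from compound 2 to compound 3; the expectation is that compound 3 again reaches only the limit.

Compound 3 is accordingly estimated at 25000 nM, with a range from 8000 nM to 60000 nM. The estimated step of a number no higher from compound 2 to compound 3 (the limit leaves the size open) is expected to be none beyond the scatter.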

Compound 3, half-maximal effective concentration: > 25000 nM
Compound 3: only a limit was reported; the forecaster's own chance of this, stated with the estimate: 80%; the middle value sits exactly at the limit.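

In this assay compound 3 also gives only a limit (> 25000 nM). No new step can be read, and the steps linking compound 1, compound 2 and compound 3 remain unreadable: the limit of > 25000 nM in this assay, at which 3 of the 3 values shown sit.

The compounds shown leave open whether any of these three tails on the shared core differs from the others in this read-out.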